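The source may hold more compounds than are shown below. What is called first, only, known or untested is meant among the compounds shown, and "the series" means these compounds.

Measured in an assay on isolated protein for inhibition of phosphatidylinositol 4,5-bisphosphate 3-kinase catalytic subunit beta isoform (Homo sapiens); on this read-out higher numbers stand for weaker inhibition and lower numbers for stronger inhibition:
Compound 1 `Cc1nn2c(O)cc(N3CCOCC3=O)nc2c1Cc1cccc(C(F)(F)F)c1C` gives 316 nM.
Compound 2 `CCc1nn2c(O)cc(-c3ccncc3)nc2c1Cc1cccc(Cl)c1Cl` gives 0.631 nM.
Compound 3 `CCc1nn2c(O)cc(C3CCOCC3)nc2c1Cc1cccc(Cl)c1Cl` gives 12.6 nM.

Among these three, compound 3 stands second highest: compound 2 is its nearest neighbour on the step of a 20-fold higher number from compound 2 to compound 3 (1.30 log units; beyond the scatter), which is beyond the scatter, while compound 1 lies furthest away with a higher number still. Compound 1 and compound 3 differ in several places at once, so only their two values can be set side by side.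

Compound 4 `Nc1nn2c(O)cc(C3CCOCC3)nc2c1Cc1cccc(Cl)c1Cl` is the next compound, not yet measured in this assay. It differs from compound 3 in one place: amino in place of ethyl on an aromatic carbon. Going by the values given here, none of the measured steps touches this position. Among the compounds with values here, the only single-point step on record, from compound 2 to compound 3, concerns the group on the six-membered ring of the core and was large; it says nothing about an exchange of ethyl for amino on the five-membered ring. Within the data shown here, with no precedent, the expected step of a 2.4-fold higher number from compound 3 to compound 4 (0.38 log units; beyond the scatter) is taken as small and undirected, and the range is kept wide. Compound 4 is therefore estimated at 30 nM, with a range from 5 nM to 200 nM.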

Compound 4, half-maximal inhibitory concentration: 7.94 nM
Beside the measured number, compound 4's estimate is 3.8-fold (0.58 log units) above it; the range from low to high includes it.
By their numbers in this assay, from the lowest: compound 2; then compounds 4 and 3 (each within the scatter of the next); then compound 1.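

On the five-membered aromatic ring, next to the ring atom that bears the 2,3-dichlorobenzyl group, the exchange of ethyl for amino gives in this assay a 1.6-fold lower number from compound 3 to compound 4 (0.20 log units; within the scatter), so this read-out does not separate the two compounds. Going by these compounds alone, this is the first measured view of the position: a group of 2 carbon atoms gives way to a single nitrogen with 1 hydrogen-bond donor and 1 hydrogen-bond acceptor, and the step stays within the scatter, whereas the exchange elsewhere on the core, a 20-fold higher number from compound 2 to compound 3 (1.30 log units; beyond the scatter), lies beyond it. Nothing available explains why this exchange leaves the number within the scatter.

Going by these compounds, the step was read only with oxan-4-yl on the core, so it remains open whether amino in place of ethyl would also stay within the scatter with the pyridin-4-yl group of compound 2. Also open, on these data alone, is how a longer chain such as propyl, a methylamino group or a carboxylic acid would behave at this same position.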